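A Methyl Added to the Weakest of Three Compounds

A few compounds are considered here, and "the series" means these few. Any claim that something is new, unique, unknown or untested is made for them only; others in the source may bear on it.

In an assay on isolated protein for inhibition of Amine oxidase [flavin-containing] A (Homo sapiens), read by fluorescence and spectrophotometry (a lower number here means a stronger inhibitor, a higher number a weaker inhibitor), compound 1 `CC(N)CSc1ccc(Br)cc1` gives 3890 nM. In this assay compound 3 `CC(N)CSc1cccc(Br)c1` gives 7820 nM. In this assay compound 2 `CC(N)C[Te]c1ccccc1` gives 25400 nM.

Compound 2 has the highest number of the three and is therefore the weakest inhibitor among them: compound 3 is the nearest, with a clearly lower number, and compound 1 is the furthest, lower still, both gaps lying beyond the scatter. Compound 4 `Cc1ccc([Te]CC(C)N)cc1` is the compound still to be tested. It differs from compound 2 in one place: methyl in place of hydrogen on an aromatic carbon, on an aromatic carbon of a six-membered aromatic ring of carbon only, para to a group of 5 heavy atoms. For the measured compounds named here, no measured pair shows this same change, so there is no step to draw on. For compound 4 the expectation is a small step in this assay, not clearly beyond the scatter, in either direction. Compound 4 is estimated at 20000 nM, between 6000 nM and 65000 nM. That estimate means an expected step of a 1.3-fold lower number from compound 2 to compound 4 (0.10 log units; within the scatter).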

Compound 4, half-maximal inhibitory concentration: 6660 nM
Estimate against measurement, compound 4: 3.0-fold (0.48 log units) above, within the range that was stated.
By their numbers in this assay, from the lowest: compounds 1, 4 and 3 (each within the scatter of the next); then compound 2.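

Methyl in place of hydrogen on an aromatic carbon, para to a group of 5 heavy atoms, gives a 3.8-fold lower number from compound 2 to compound 4 (0.58 log units; beyond the scatter) in this assay. For the compounds shown here, the earlier compounds offered no pair differing in one place, so this is the first single change that can be read, and it shows that one added carbon at this position can move the number beyond the scatter. No measurement shown here bears on why the number falls.

Going by these compounds, what an ethyl group, a methoxy group or a chlorine atom would do at this same place remains open. So does the effect of a methyl group on another carbon of the ring.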